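Phenyl in place of tert-butyl on the carbonyl carbon

This account rests on a few compounds, and the source may have more. Where it says the series, first, only, none or still open, it means among the compounds named here.

Within the data shown here, in a functional assay on RPMI-8226 cells (Homo sapiens) for cytotoxicity, read by MTT assay, with a stated time of 48 h (a lower number here means a stronger inhibitor, a higher number a weaker inhibitor), compound 2 `CC(C)(C)C(=O)NN=C1C(Cl)=C(Cl)C(Cl)=C1Cl` gives 90 nM and holds the only true number so far. Compound 1 `C#CC(C)(C)OC(=O)NN=C1C(Cl)=C(Cl)C(Cl)=C1Cl` shares the core and reads > 5000 nM in this assay and this reading is a limit of the assay, not a number. Among the measured compounds shown here, the single measured step is an at least 55-fold lower number from compound 1 to compound 2 (1.74 log units; beyond the scatter) and it shows that the group on this carbonyl carbon can matter a great deal. Compound 3 `O=C(NN=C1C(Cl)=C(Cl)C(Cl)=C1Cl)c1ccccc1` brings the next change: phenyl in place of tert-butyl on a carbonyl carbon with phenyl in place of tert-butyl on a carbonyl carbon. That one step involved a different group and gives no firm direction here, so only a modest weakening is expected in this assay with a wide margin. The expected step is a 2.2-fold higher number from compound 2 to compound 3 (0.35 log units; beyond the scatter) and it remains a cautious guess. For compound 3 the estimated value is 200 nM with an expected range from 40 nM to 1500 nM in this assay.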

Compound 3, half-maximal inhibitory concentration: 600 nM
For compound 3 the middle estimate is 3.0-fold (0.48 log units) below the measured one; measured number inside the range.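

In this assay phenyl in place of tert-butyl gives a 6.7-fold higher number from compound 2 to compound 3 (0.82 log units; beyond the scatter) and so shows that this position separates even two groups made only of carbon, neither with a hydrogen-bond donor or acceptor. Phenyl in place of (1,1-dimethylprop-2-yn-1-yl)oxy still gives an at least 8.3-fold lower number from compound 1 to compound 3 (0.92 log units; beyond the scatter) and so places phenyl between the other two groups, with tert-butyl giving the lowest number of the three. The size of that second step is only a bound, since compound 1 stands at a limit and not at a true number: the limit of > 5000 nM in this assay, at which 1 of the 3 values shown sits.

The compounds shown do not tell why phenyl reads weaker than tert-butyl. Going by these compounds, how a longer alkyl chain or an amine on the carbonyl carbon would read also remains open.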